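Swapping a Hydroxamate for a Carboxyphenyl Amide

The compounds below may be only part of what the source reports. "The series", "measured", "known", "first", "only" and "open" are said of these compounds alone.

Measured compounds:
- compound 1, `CC(C)=CCCC1=CC[C@H](C(=O)N(C)O)[C@@H](c2ccccc2)C1`, 2100 nM
- compound 2, `CC1(C)CCCC2=C1C[C@H](C(=O)O)[C@@H](c1ccccc1)C2`, > 23000 nM

For the measured compounds named here, only two compounds have been measured in an assay on isolated protein for inhibition of Apoptosis regulator Bcl-2 (Homo sapiens), read by fluorescence polarization, with stated times of 5 min and 10 min; on this read-out higher numbers stand for weaker inhibition and lower numbers for stronger inhibition. Going by the values given here, compound 1 is the only one with an actual number, giving 2100 nM in this assay. Compound 2 reaches only a limit of the assay, > 23000 nM, so its true value is not known; the limit of > 23000 nM in this assay, at which 1 of the 2 values shown sits, is where one of the two results sits. Among the compounds with values here, compound 1 therefore stands alone as the single reference point, and no step between measured compounds can be drawn.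

The unmeasured compound 3, `CC(C)=CCCC1=CC[C@H](C(=O)Nc2ccc(C(=O)O)cc2)[C@@H](c2ccccc2)C1`, differs from compound 1 in one place: (4-carboxyphenyl)amino in place of hydroxy(methyl)amino on a carbonyl carbon. The shared core of compound 1 is kept unchanged. Within the data shown here, with no measured step to lean on, the direction of this change cannot be read from the data; a moderate shift in this assay, most likely toward stronger inhibition, is expected, though a result within the scatter would not surprise. The step from compound 1 to compound 3 is expected to be a 2.3-fold lower number from compound 1 to compound 3 (0.37 log units; beyond the scatter). Compound 3 is estimated at 900 nM, somewhere between 250 nM and 4000 nM.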

Compound 3, inhibition constant: > 23000 nM
Compound 3: a limit, no number; the forecaster's own chance of this, stated with the estimate: 5%; middle value at least 25-fold (1.40 log units) from the limit.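

In this assay compound 3 gives > 23000 nM, which is a limit of the assay and not a number. Putting (4-carboxyphenyl)amino in place of hydroxy(methyl)amino on a carbonyl carbon, with the shared core unchanged, produces an at least 10-fold higher number from compound 1 to compound 3 (1.03 log units; beyond the scatter), so the group on this carbonyl carbon has a large effect on inhibition, and this swap weakens it rather than strengthens it. The true size of the loss stays hidden because the value of compound 3 gives only a limit, one that another compound shares: the limit of > 23000 nM in this assay, at which 2 of the 3 values shown sit.

The compounds shown leave open which part of the entering group carries the loss, the aromatic ring or the carboxyl group, as both arrive in a single step. They also leave open how a plain phenylamino group or a simple methylamino group would fare on the same carbonyl carbon, and such groups would show whether the loss follows the ring, the carboxyl group or the removal of hydroxy(methyl)amino.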